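The source may report more compounds than this note shows. Statements on the series, on what has been measured and on what is new or still open speak of the compounds shown alone.

Working notes on the series, read in a functional assay on HeLa cells (Homo sapiens) for cytotoxicity, read by MTT assay, with a stated time of 72 h; a lower number here means a stronger inhibitor, a higher number a weaker inhibitor: compound 1 (`C#C[C@H](O)/C=C/CCCCC/C=C\CCCC/C=C\CCCCCCCCC/C=C/[C@@H](O)C#C`) gives 260 nM and compound 2 (`C#C[C@H](O)/C=C/CCCCCCC/C=C\CCCC/C=C\CCCCCCCCC/C=C/[C@@H](O)C#C`) gives 100 nM, so compound 2 holds the lower of the two numbers measured so far. Compound 3 (`C#C[C@H](O)/C=C/CCCCCCCCC/C=C\CCCC/C=C\CCCCCCCCC/C=C/[C@@H](O)C#C`) is the next structure to read, and it differs from compound 2 as follows: a group of 8 heavy atoms (7 carbon, 1 oxygen; no ring) in place of a group of 6 heavy atoms (5 carbon, 1 oxygen; no ring), on a saturated chain carbon, seven bonds along the chain from a double-bonded chain carbon. Among the compounds with values here, one measured step bears on this, a change of the same kind made five bonds along the chain from a double-bonded chain carbon: a 2.6-fold lower number from compound 1 to compound 2 (0.41 log units; beyond the scatter). That step is modest but beyond the scatter, and a single step cannot establish a trend. On that basis, a further modest move towards a lower number is expected in this assay, with no change beyond the scatter also possible. The expected step is a 1.5-fold lower number from compound 2 to compound 3 (0.19 log units; within the scatter). The estimate for compound 3 is 65 nM, with an expected range from 25 nM to 170 nM.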

Compound 3, half-maximal inhibitory concentration: 80 nM
Compound 3: middle estimate off by 1.2-fold (0.09 log units), on the low side, and the stated range covers the measured number.
By their numbers in this assay, from the lowest: compounds 3 and 2 (each within the scatter of the next); then compound 1.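

At the position seven bonds along the chain from a double-bonded chain carbon, the exchange of the group of 6 heavy atoms for the group of 8 heavy atoms gives a 1.3-fold lower number from compound 2 to compound 3 (0.10 log units; within the scatter) in this assay, so compounds 2 and 3 cannot be told apart here, whereas the earlier step, a 2.6-fold lower number from compound 1 to compound 2 (0.41 log units; beyond the scatter), was larger than the scatter. Over the whole span the result is a 3.3-fold lower number from compound 1 to compound 3 (0.51 log units; beyond the scatter), and across these three compounds the separation rests on compound 1 alone, with no further gain resolved past compound 2. No measurement in hand explains this levelling of the numbers.

As far as these compounds go, whether a longer chain at this place would keep the number close to that of compound 3 or shift it remains open. Also open, from the compounds shown here alone, is how a carboxylic acid or an amine at the chain end would read in this assay against these all-carbon chains.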